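Aryl variation on the fused core: compound 3 estimate

The source may report more compounds than this note shows. Statements on the series, on what has been measured and on what is new or still open speak of the compounds shown alone.

Measured so far:
compound 1 `CC#CC(CC(=O)O)c1ccc(OCc2ccn3cc(-c4ccc(C)cc4C)nc3c2)cc1`: 503 nM
compound 2 `CC#CC(CC(=O)O)c1ccc(OCc2ccn3cc(-c4ccc(C(F)(F)F)cc4)nc3c2)cc1`: 674 nM

In an assay on isolated protein for agonist activity at Free fatty acid receptor 1 (Homo sapiens) (a higher number here means that more compound is needed for the effect, a lower number that less compound is needed), compound 2 gives 674 nM and compound 1 gives 503 nM; the two lie within the scatter of each other, the step of a 1.3-fold higher number from compound 1 to compound 2 (0.13 log units; within the scatter) being small, so compound 2 is not set apart from compound 1 on these numbers. Compound 3 `CC#CC(CC(=O)O)c1ccc(OCc2ccn3cc(-c4ccc(F)cc4F)nc3c2)cc1` carries 2,4-difluorophenyl in place of 4-(trifluoromethyl)phenyl on an aromatic carbon. Among the compounds with values here, the only step that bears on this change is that aryl swap, and it barely moved the number, so no shift beyond the scatter is expected here. Compound 3 is therefore estimated at 560 nM, between 250 nM and 1250 nM, an expected step of a 1.2-fold lower number from compound 2 to compound 3 (0.08 log units; within the scatter).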

Compound 3, half-maximal effective concentration: 792 nM
Beside the measured number, compound 3's estimate is 1.4-fold (0.15 log units) below it; the measured number falls inside the stated range.
By their numbers in this assay, from the lowest: compounds 1, 2 and 3 (each within the scatter of the next).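

Placing 2,4-difluorophenyl on this aromatic carbon of the five-membered ring gives a 1.2-fold higher number from compound 2 to compound 3 (0.07 log units; within the scatter) and a 1.6-fold higher number from compound 1 to compound 3 (0.20 log units; within the scatter) in this assay for the two earlier aryl groups. Fluorine on the ring at the 2,4-pattern therefore joins 2,4-dimethylphenyl and 4-(trifluoromethyl)phenyl as a third substituted phenyl that is not set apart from the others, so the position now shows no separation across three aryl groups. No outside data bear on these numbers.

Still open, on these data alone, is whether any group here can move the number beyond the scatter. An aryl ring carrying an amine or a carboxylic acid, or a saturated ring such as cyclohexyl, would test that.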